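Chloro for bromo in two sulfonamide series

The compounds below may be only part of what the source reports. "The series", "measured", "known", "first", "only" and "open" are said of these compounds alone.

Measured so far:
compound 1 `NS(=O)(=O)c1ccc(C(=O)N/N=C\c2ccc(Br)cc2)cc1` — 27700 nM
compound 2 `NS(=O)(=O)c1ccc(C(=O)N/N=C\c2ccc(Cl)cc2)cc1` — 82000 nM
compound 3 `NS(=O)(=O)c1ccc(N/C=C(\C(=O)c2ccc(Br)cc2)S(=O)(=O)c2ccccc2)cc1` — 20400 nM

In an ADME assay on MCF-10A cells (Homo sapiens) for antiproliferative activity, read by MTT assay (on this read-out higher numbers stand for weaker inhibition and lower numbers for stronger inhibition), compound 1 gives 27700 nM. Compound 2 carries the change chloro in place of bromo on an aromatic carbon and in this assay compound 2 gives 82000 nM; the step is a 3.0-fold higher number from compound 1 to compound 2 (0.47 log units; beyond the scatter). Compound 3 rests on a different core; how the two cores differ is not broken down here. In this assay compound 3 gives 20400 nM, which sits within the scatter of compound 1 and beyond the scatter of compound 2, so no order between compound 3 and compound 1 is read.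

Compound 4 `NS(=O)(=O)c1ccc(N/C=C(\C(=O)c2ccc(Cl)cc2)S(=O)(=O)c2ccccc2)cc1` has not been measured. It carries the change (chloro in place of bromo on an aromatic carbon), the same change on the same kind of place as that from compound 1 to compound 2. Among the measured compounds shown here, only one earlier instance of the change exists, on the other core, so the transfer is uncertain. For the measured compounds named here, on compound 3 the step is expected to be a 2.5-fold higher number from compound 3 to compound 4 (0.39 log units; beyond the scatter), a modest rise in the number because the one earlier instance gave a 3.0-fold higher number from compound 1 to compound 2 (0.47 log units; beyond the scatter). In this assay compound 4 is estimated at 50000 nM, with a range from 20000 nM to 120000 nM.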

Compound 4, half-maximal inhibitory concentration: 28000 nM
Compound 4: the middle estimate sits 1.8-fold (0.25 log units) above what was measured; low and high end bracket the measured number.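

In this assay, chloro in place of bromo on the core of compound 3 gives a 1.4-fold higher number from compound 3 to compound 4 (0.14 log units; within the scatter), so compound 3 and compound 4 cannot be ordered. Set beside the earlier instance, the two steps cannot be told apart: the same change on two cores in this assay, a 3.0-fold higher number (0.47 log units; beyond the scatter) from compound 1 to compound 2 and a 1.4-fold higher number (0.14 log units; within the scatter) from compound 3 to compound 4, 2.2-fold (0.33 log units) apart, within the scatter of two such steps. Among the compounds shown here, the two results are therefore compatible with a single step size shared by both cores, but they do not show that the step carries over, since it lies beyond the scatter on one core and within it on the other, and each core supplies only one pair.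

The compounds shown leave open how fluoro, methyl or an amine in the same place would read on either core, as only bromo and chloro appear there. They also leave open whether the step seen on these two cores would hold on a third core.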